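This account rests on a few compounds, and the source may have more. Where it says the series, first, only, none or still open, it means among the compounds named here.

Among the compounds with values here, in an ADME assay on HEK293 cells (Homo sapiens) for cytotoxicity, read by resazurin assay, with a stated time of 48 h (on this read-out lower numbers stand for higher toxicity in this test and higher numbers for lower toxicity in this test), compound 1 `Cc1ccccc1S(=O)(=O)Nc1ccc2oc(-c3ccccc3)nc2c1` gives 57000 nM, and this is the only true number available so far. Compound 2 `O=S(=O)(Nc1ccc2oc(-c3ccccc3)nc2c1)c1ccc(F)c(C(F)(F)F)c1` gives > 100000 nM, which is a limit and not a number. With so little data, compound 1 has no measured neighbour to be ranked against, and it serves as the reference point.

Compound 3 `O=S(=O)(Nc1ccc2oc(-c3ccccc3)nc2c1)c1ccc(Cl)cc1` has not yet been measured in this assay. It differs from compound 1 in one place, 4-chlorophenyl in place of 2-methylphenyl on a sulfonyl sulfur.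

Within the data shown here, no measured pair of compounds isolates a single change, so the size of this swap cannot be read directly from the data. The anchor is compound 1 at 57000 nM. The only other result is the limit reached by compound 2, so any lean is slight and towards lower toxicity. The estimated step is a 1.2-fold higher number from compound 1 to compound 3 (0.09 log units; within the scatter), which is expected to stay within the usual scatter. For compound 3, the expected value is 70000 nM, with an estimated range of 30000 nM to 100000 nM.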

Compound 3, half-maximal cytotoxic concentration: 65000 nM
Beside the measured number, compound 3's estimate is 1.1-fold (0.03 log units) above it; measured number inside the range.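

Within the data shown here, compound 3 gives the first step that isolates one change at this position: in this assay, placing 4-chlorophenyl where 2-methylphenyl sat on the sulfonyl sulfur gives a 1.1-fold higher number from compound 1 to compound 3 (0.06 log units; within the scatter). The two values cannot be told apart in this test, so this particular swap, between two groups that each hold one six-membered aromatic ring of carbon and the same count of heavy atoms, leaves the read-out within its usual scatter. Among these compounds, compound 2 gives > 100000 nM, which is a limit and not a number, so it adds no measured step at this position.

Nothing shown here bears on why these two groups read alike in this test. Going by these compounds, it remains open whether a group of another kind on the sulfonyl sulfur, such as an amine, a carboxylic acid or a longer carbon chain, would move the number beyond the scatter, and whether a change elsewhere on the shared core would do so.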